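Compound 4: hydrogen in place of hydroxy

A few compounds are considered here, and "the series" means these few. Any claim that something is new, unique, unknown or untested is made for them only; others in the source may bear on it.

Values in a functional assay on HeLa cells (Homo sapiens) for inhibition, read by MTT assay, with a stated time of 72 h; on this read-out higher numbers stand for weaker inhibition and lower numbers for stronger inhibition:
- compound 1 `O=[N+]([O-])c1ccc(-c2nnc(SCCCN3CCN(c4nc5ccccc5o4)CC3)o2)cc1`: 114000 nM
- compound 2 `Fc1ccc(-c2nnc(SCCCN3CCN(c4nc5ccccc5o4)CC3)o2)cc1`: 196000 nM
- compound 3 `Oc1ccc(-c2nnc(SCCCN3CCN(c4nc5ccccc5o4)CC3)o2)cc1`: 99500 nM

Going by the values given here, the three values sit together, and no compound can be ranked above another. The measured steps are a 1.7-fold higher number from compound 1 to compound 2 (0.24 log units; within the scatter), a 1.1-fold lower number from compound 1 to compound 3 (0.06 log units; within the scatter) and a 2.0-fold lower number from compound 2 to compound 3 (0.29 log units; within the scatter). Compound 3, at 99500 nM, therefore belongs to this single group and holds no separate place in this assay.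

The next structure is compound 4 `c1ccc(-c2nnc(SCCCN3CCN(c4nc5ccccc5o4)CC3)o2)cc1`. Here hydrogen stands in place of hydroxy on an aromatic carbon, para to a large group, turning 4-hydroxyphenyl into phenyl: hydrogen in place of hydroxy on an aromatic carbon.

All three measured steps bear on this change, since each exchanges one group for another on an aromatic carbon. Among these three compounds, no exchange has moved the value beyond the scatter. Among the compounds with values here, no measured compound yet carries hydrogen at this carbon, so the expectation is an extrapolation. No step beyond the scatter is expected in this assay, and the expected change is a 1.3-fold higher number from compound 3 to compound 4 (0.12 log units; within the scatter). For compound 4 the estimated value is 130000 nM, with an expected range from 70000 nM to 240000 nM.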

Compound 4, half-maximal inhibitory concentration: 67000 nM
Compound 4: the middle estimate sits 1.9-fold (0.29 log units) above what was measured; the measured number lies below the stated range.
By their numbers in this assay, from the lowest: compounds 4, 3, 1 and 2 (each within the scatter of the next, the first and the last beyond it).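

Working notes on the aromatic carbon: in (this assay), the exchange of fluoro for hydrogen gives the only step in the set that passes the scatter, and it is modest (a 2.9-fold lower number from compound 2 to compound 4 (0.47 log units; beyond the scatter)). The change from 4-hydroxyphenyl to phenyl stays within the scatter (a 1.5-fold lower number from compound 3 to compound 4 (0.17 log units; within the scatter)), as does the exchange of nitro for hydrogen (a 1.7-fold lower number from compound 1 to compound 4 (0.23 log units; within the scatter)), so compound 4 cannot be ranked against either compound 3 or compound 1. Going by these compounds alone, the series therefore now has a separation at its two ends, but it rests on the single pair of compound 2 and compound 4, and the bare phenyl shows that none of the three substituents is needed at this carbon to keep a value in this range.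

An amine, a carboxylic acid or a methoxy group on this carbon remains untested in the compounds shown, as does a longer chain in place of the one linking the sulfur to the piperazine-bearing end of the shared core. Within the data shown here, no available measurement accounts for the one step that passes the scatter.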